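The source may report more compounds than this note shows. Statements on the series, on what has been measured and on what is new or still open speak of the compounds shown alone.

Among the measured compounds shown here, in a functional assay on KB cells (Homo sapiens) for antiproliferative activity, read by MTT assay, with a stated time of 72 h (a lower number here means a stronger inhibitor, a higher number a weaker inhibitor), compound 2 `N#Cc1cccc(NC(=O)C(Cl)Cl)c1` gives 60900 nM, the higher of the two numbers measured so far; compound 1 `O=C(Nc1cccc(Br)c1)C(Cl)Cl` gives 8180 nM, and the single step recorded between them is a 7.4-fold higher number from compound 1 to compound 2 (0.87 log units; beyond the scatter). Compound 3 `COc1cccc(NC(=O)C(Cl)Cl)c1` differs from compound 2 by methoxy in place of cyano on an aromatic carbon. For the measured compounds named here, no measured step sets methoxy against cyano on this ring, so that one step shows only that swapping the group there can shift this assay by a modest amount. Compound 3 is expected to move part of the way back toward compound 1, a 3.0-fold lower number from compound 2 to compound 3 (0.48 log units; beyond the scatter). Compound 3 is therefore estimated at 20000 nM, between 6000 nM and 70000 nM.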

Compound 3, half-maximal inhibitory concentration: 57700 nM
Compound 3: the middle estimate sits 2.9-fold (0.46 log units) below what was measured, within the range that was stated.
By their numbers in this assay, from the lowest: compound 1; then compounds 3 and 2 (each within the scatter of the next).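

On this aromatic carbon, methoxy and cyano give numbers that cannot be told apart (a 1.1-fold lower number from compound 2 to compound 3 (0.02 log units; within the scatter)). Methoxy in place of bromo gives a step beyond the scatter (a 7.1-fold higher number from compound 1 to compound 3 (0.85 log units; beyond the scatter)), so the gap first seen with cyano also appears with a second group, leaving compound 1 apart from compound 2 and compound 3. No measured evidence on the cause of this gap is available. On these data alone, it remains open whether an amine, a carboxylic acid or chloro on this carbon would match bromo or the other two groups. As far as these compounds go, it also remains open whether the gap from bromo would hold on another carbon of the ring.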